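The source may hold more compounds than are shown below. What is called first, only, known or untested is meant among the compounds shown, and "the series" means these compounds.

Measured compounds:
- compound 1 `CCCCCc1ccc(C#Cc2cn([C@@H]3O[C@H](CO)[C@@H](O)[C@H](O)[C@H]3O)c(=O)nc2N)cc1`: 132000 nM
- compound 2 `CC(C)(C)c1ccc(C#Cc2cn([C@@H]3O[C@H](CO)[C@@H](O)[C@H](O)[C@H]3O)c(=O)nc2N)cc1`: a limit, > 250000 nM
- compound 3 `CCCc1cc2cn([C@@H]3O[C@H](CO)[C@@H](O)[C@H](O)[C@H]3O)c(=O)nc2o1`: 132000 nM

In a functional assay on L1210 cells (Mus musculus) for cytotoxicity, with a stated time of 48 h (on this read-out higher numbers stand for weaker inhibition and lower numbers for stronger inhibition), compound 3 gives 132000 nM, level with compound 1 at the digits shown. Compound 2 gives only a limit of the assay, > 250000 nM, not a number (the limit of > 250000 nM in this assay, at which 1 of the 3 values shown sits). Compound 4 `CCCCCc1cc2cn([C@@H]3O[C@H](CO)[C@@H](O)[C@H](O)[C@H]3O)c(=O)nc2o1` differs from compound 3 by ethyl in place of hydrogen on a saturated chain carbon, three bonds along the chain from an aromatic carbon, so that propyl becomes pentyl. Among the compounds with values here, the only measured step swaps pentyl for tert-butyl, an at least 1.8-fold higher number from compound 1 to compound 2 (0.27 log units; that floor lies within the scatter), and its floor sits within the scatter; it does not test a longer chain. No shown step therefore points to a change beyond the scatter, and compound 4 is expected to stay near compound 3, a step of no change at the digits printed from compound 3 to compound 4 (within the scatter). The estimate for compound 4 is 132000 nM, between 60000 nM and 300000 nM.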

Compound 4, half-maximal inhibitory concentration: >= 250000 nM
Compound 4: no number, only a limit; the forecaster's own chance of this, stated with the estimate: 25%; middle value at least 1.8-fold (0.27 log units) from the limit.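

Swapping hydrogen for ethyl turns the propyl of compound 3 into pentyl, and this is the one step shown that tests a longer chain at this place: in this assay it reads an at least 1.8-fold higher number from compound 3 to compound 4 (0.27 log units; that floor lies within the scatter). Compound 4 gives only a limit, not a number: the limit of >= 250000 nM in this assay, at which 1 of the 4 values shown sits.

Going by these compounds, on this core, then, pentyl gives no lower number than propyl, though the true size of the step stays unknown. On these data alone, whether a shorter chain such as ethyl, or a propyl chain ending in an amine or a carboxylic acid, would give a lower number remains open.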